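The source may hold more compounds than are shown below. What is called first, only, known or untested is meant among the compounds shown, and "the series" means these compounds.

Compound 1 `NCC(O)Cn1c(=O)n(C2OC(CO)[C@@H](O)[C@H]2O)c2nc(N)nc(O)c21` and compound 2 `C=CCn1c(=O)n(C2OC(CO[Si](c3ccccc3)(c3ccccc3)C(C)(C)C)[C@@H](O)[C@H]2O)c2nc(N)nc(O)c21` have the same core and differ only in one side chain. In a functional assay (B cells) with Mus musculus as the target (a higher number here means that more compound is needed for the effect, a lower number that less compound is needed), compound 1 gives 28 uM, the higher of the two numbers shown, and compound 2 gives 18 uM; the two values lie within the usual scatter of each other. Compound 3 `CCOC(=O)Cn1c(=O)n(C2OC(CO)[C@@H](O)[C@H]2O)c2nc(N)nc(O)c21` comes from compound 1 through a single change: ethoxycarbonyl in place of 2-amino-1-hydroxyethyl on a saturated chain carbon bound to an aromatic nitrogen. Going by the values given here, no measured pair shows this change, so its effect is not known. Compound 3 is expected to give about 30 uM, with a likely range from 10 uM to 90 uM. The step of a 1.1-fold higher number from compound 1 to compound 3 (0.03 log units; within the scatter) is estimated to stay within the scatter.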

Compound 3, concentration for half-maximal effect: 48 uM
The estimate for compound 3 lay 1.6-fold (0.20 log units) below the measured number; the range from low to high includes it.
By their numbers in this assay, from the lowest: compounds 2, 1 and 3 (each within the scatter of the next, the first and the last beyond it).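

In this assay, ethoxycarbonyl in place of 2-amino-1-hydroxyethyl gives a 1.7-fold higher number from compound 1 to compound 3 (0.23 log units; within the scatter) on a saturated chain carbon bound to an aromatic nitrogen. The step stays within the scatter, although the group that leaves has 2 hydrogen-bond donors and the one that enters has 0. No measurement shown gives a reason for this result. On these data alone, it remains open whether a carboxylic acid or a simple primary amine on this chain, or a longer chain, would also stay within the scatter of compound 1.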